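A few compounds are considered here, and "the series" means these few. Any claim that something is new, unique, unknown or untested is made for them only; others in the source may bear on it.

Within the data shown here, compound 1 `CC1CC(=O)N(c2ccccc2C(=O)OCC2CCCN(CCCCCOc3ccccc3)C2)C1=O` is one of two compounds measured in an in vitro functional assay on HEK ts201 cells for antagonist activity at Neuronal acetylcholine receptor; alpha4/beta2 (Homo sapiens), read by fluorescence and calcium flux; on this read-out lower numbers stand for stronger inhibition and higher numbers for weaker inhibition; in this assay compound 1 gives 17000 nM, the higher of the two numbers recorded. The other, compound 2 `O=C(CCC1CCCNC1)c1ccccc1-c1ccccc1`, gives 9120 nM in this assay, a value that lies within the scatter of that for compound 1, so no order between the two can be stated. Compound 3 `CC1CC(=O)N(c2ccccc2C(=O)OCC2CCCN(CCCCOc3ccc(Cl)c(Cl)c3)C2)C1=O` shares the core of compound 1 and differs from it in one place: 3,4-dichlorophenoxy in place of phenoxymethyl on a saturated chain carbon, four bonds along the chain from an amine nitrogen in a ring. Among the measured compounds shown here, no measured pair in this set isolates such a change, so the size of its effect rests on expectation alone. Given the weak inhibition shown by compound 1 at 17000 nM, a modest step of a 1.7-fold lower number from compound 1 to compound 3 (0.23 log units; within the scatter) toward stronger inhibition is expected for compound 3, though one not clearly beyond the scatter. Compound 3 is therefore estimated at 10000 nM, with a range from 3000 nM to 40000 nM.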

Compound 3, half-maximal inhibitory concentration: 12300 nM
Estimate against measurement, compound 3: 1.2-fold (0.09 log units) below; the range from low to high includes it.
By their numbers in this assay, from the lowest: compounds 2, 3 and 1 (each within the scatter of the next).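

In this assay, 3,4-dichlorophenoxy in place of phenoxymethyl at this position, on a saturated chain carbon, four bonds along the chain from an amine nitrogen in a ring, gives a 1.4-fold lower number from compound 1 to compound 3 (0.14 log units; within the scatter) and so sets no order between the two compounds. Among these compounds, this is the first pair in the set that isolates a change at this place, and it shows that this particular exchange, which brings in two chlorine atoms and alters the chain as well, leaves the number within the scatter. Nothing measured here offers a reason for this result.

The pair cannot separate the chlorine atoms from the change in the chain. It also leaves open whether a methoxy group, a nitrile or a carboxylic acid on the phenoxy ring, or a longer chain, would move the number beyond the scatter.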